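The compounds below may be only part of what the source reports. "The series", "measured", "known", "first", "only" and "open" are said of these compounds alone.

Measured so far in a functional assay on CHO cells with metabotropic glutamate receptor 2 (Homo sapiens) as the target, read by GTPgammaS binding; on this read-out higher numbers stand for larger maximal responses and lower numbers for smaller maximal responses:
- compound 1, `CCc1cnc2c(C#N)c(N3CCN(c4nc(C)cc(C)n4)CC3)ccn12`: 142%
- compound 2, `CCc1cnc2c(C#N)c(N3CCN(c4ncccn4)CC3)ccn12`: 214%

Compound 2 stands highest of the two numbers in this assay; the nearest is compound 1, and the step of a number 72 percentage points higher from compound 1 to compound 2 (beyond the scatter) lies beyond the scatter, so compound 2 gives the larger maximal response. Compound 3, `N#Cc1c(N2CCN(c3ncccn3)CC2)ccn2c(CCC3CC3)cnc12`, has not yet been measured in this assay. It differs from compound 2 by cyclopropyl in place of hydrogen on a saturated chain carbon, two bonds along the chain from an aromatic carbon. For the measured compounds named here, no measured step bears on this change: the only step known, a number 72 percentage points higher from compound 1 to compound 2 (beyond the scatter), concerns a different part of the molecule, the pyrimidinyl group on the amine nitrogen in the ring, and says nothing about the chain on the core. Going by the values given here, with no comparable step to lean on, the expectation for compound 3 is a step of about a number 14 percentage points lower from compound 2 to compound 3 (beyond the scatter), that is none beyond the scatter, with a wide range. Compound 3 is therefore estimated at 200% in this assay, between 140% and 260%.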

Compound 3, largest response reached (Emax), in percent of the reference or control that the assay uses: 229%
The estimate for compound 3 lay 29 percentage points below the measured number; the range from low to high includes it.
By their numbers in this assay, from the lowest: compound 1; then compound 2; then compound 3.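

With the chain on the shared core, replacing ethyl by 2-cyclopropylethyl gives a number 15 percentage points higher from compound 2 to compound 3 (beyond the scatter) in this assay. For the compounds shown here, the earlier compounds varied only the pyrimidinyl group on the amine nitrogen in the ring, so this is the first sign that a cyclopropyl on a saturated chain carbon, two bonds along the chain from an aromatic carbon, is compatible with a large maximal response and can even raise it modestly. Nothing available explains this rise.

The compounds shown leave open whether a plain butyl chain would do the same as the cyclopropyl, and how an amine or a hydroxyl group at the end of that chain would read. They also leave open whether the same step would hold with 4,6-dimethylpyrimidin-2-yl on the amine nitrogen.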